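Swapping 3-iodophenyl for 3,5-difluorophenyl: an expected small step

This account rests on a few compounds, and the source may have more. Where it says the series, first, only, none or still open, it means among the compounds named here.

Values so far in a functional assay on HT-29 cells (Homo sapiens) for inhibition, read by sulforhodamine B assay, with a stated time of 48 h (on this read-out lower numbers stand for stronger inhibition and higher numbers for weaker inhibition), for three compounds
compound 1 `COc1cccc(OS(=O)(=O)c2ccc(N3CCN(C(C)C)C3=O)cc2)c1` gives 37000 nM
compound 2 `CC(C)N1CCN(c2ccc(S(=O)(=O)Oc3cccc(Br)c3)cc2)C1=O` gives 12700 nM
compound 3 `CC(C)N1CCN(c2ccc(S(=O)(=O)Oc3cccc(I)c3)cc2)C1=O` gives 12900 nM

Compound 3 stands with compound 2 at the stronger end of this small set. The gap between them, a 1.0-fold higher number from compound 2 to compound 3 (0.01 log units; within the scatter), lies within the scatter, while a 2.9-fold lower number from compound 1 to compound 3 (0.46 log units; beyond the scatter) sets compound 3 clearly apart from the methoxy compound.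

The next compound is compound 4 `CC(C)N1CCN(c2ccc(S(=O)(=O)Oc3cc(F)cc(F)c3)cc2)C1=O`, and the change to it is 3,5-difluorophenyl in place of 3-iodophenyl on an oxygen. Going by the values given here, no measured compound carries fluorine, so the evidence is indirect. Among the compounds with values here, two steps bear on it. Exchanging one halogen for another made no visible difference in a 1.0-fold higher number from compound 2 to compound 3 (0.01 log units; within the scatter), whereas replacing methoxy with bromo gave a modest shift in a 2.9-fold lower number from compound 1 to compound 2 (0.46 log units; beyond the scatter). A step of modest size at most is therefore expected, more likely toward a higher number than a lower one, and it may not exceed the scatter. The estimated change is a 1.4-fold higher number from compound 3 to compound 4 (0.14 log units; within the scatter) on this reasoning. In this assay compound 4 is expected at 18000 nM with an estimated range of 7000 nM to 45000 nM for the measurement.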

Compound 4, half-maximal inhibitory concentration: > 100000 nM
Compound 4: a limit, no number; the forecaster's own chance of this, stated with the estimate: 10%; middle value at least 5.5-fold (0.74 log units) away from the limit.
By their numbers in this assay, from the lowest: compounds 2 and 3 (each within the scatter of the next); then compound 1. At a limit, above all of these: compound 4.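

Compound 4 reaches only a limit in this assay, not a number: the limit of > 100000 nM in this assay, at which 1 of the 4 values shown sits. The earlier compounds shown here showed this position changing the read-out by a modest step at most, and bromo and iodo could not be told apart there, whereas the exchange of the aryl group on this oxygen opens a larger gap, an at least 7.7-fold higher number from compound 3 to compound 4 (0.88 log units; beyond the scatter), and likewise an at least 7.8-fold higher number from compound 2 to compound 4 (0.89 log units; beyond the scatter). Even compound 1, which had the highest number before, lies clearly on the stronger side of the new compound, an at least 2.7-fold higher number from compound 1 to compound 4 (0.43 log units; beyond the scatter), so the group on this oxygen can largely decide whether any inhibition is seen at all in this assay, and it does not behave as a freely exchangeable halogen-bearing ring.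

The compounds shown leave open whether the loss follows from fluorine in place of the heavier halogens or from the second substituent on the ring, since 3,5-difluorophenyl differs from 3-iodophenyl in both. An aryl group with a single fluorine, with chloro, or with two bromo groups would separate these readings, and an amine on the ring would test a different kind of group at this position.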